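Shortening a Butyl Chain on a Pain-Relief Scaffold

The source may report more compounds than this note shows. Statements on the series, on what has been measured and on what is new or still open speak of the compounds shown alone.

Of the compounds shown here, three sharing one core have been tested in a functional assay on the whole organism with Mus musculus as the target, in the writhing test; on this read-out lower numbers stand for an effect already at smaller amounts and higher numbers for an effect only at larger amounts of compound. Compound 1 `CCCCn1nc2oc(=O)cc(C)c2c1C` carries a butyl chain on an aromatic nitrogen. In this assay compound 1 gives only a limit, > 100 mg/kg. Compound 1 thus stands at the limit of > 100 mg/kg in this assay, at which 1 of the 3 values shown sits, so no number places it relative to the others. Compound 2 `Cc1cc(=O)oc2c1c(C)nn2C` gives 11.6 mg/kg in this assay, and compound 3 `CCn1nc(C)c2c(C)cc(=O)oc21` gives 24.9 mg/kg. Within the data shown here, the one step between measured compounds, a 2.1-fold higher number from compound 2 to compound 3 (0.33 log units; beyond the scatter), shows that a longer chain on the nitrogen goes with a higher number.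

Compound 4 `CCCn1nc2oc(=O)cc(C)c2c1C` differs from compound 1 by hydrogen in place of methyl on a saturated chain carbon, three bonds along the chain from an aromatic nitrogen, that is, butyl to propyl. The step from compound 2 to compound 3 runs the opposite way, adding a carbon, and there the number rose modestly; removing a carbon is therefore expected to lower the number somewhat. Since compound 1 shows only a limit, the starting point is uncertain. Compound 4 is expected at 70 mg/kg, within 25 mg/kg to 200 mg/kg, an estimated step of an at least 1.4-fold lower number from compound 1 to compound 4 (0.15 log units; that floor lies within the scatter).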

Compound 4, dose for half-maximal effect: 72.6 mg/kg
For compound 4 the middle estimate is 1.0-fold (0.02 log units) below the measured one; the range from low to high includes it.
By their numbers in this assay, from the lowest: compound 2; then compound 3; then compound 4. At a limit, above all of these: compound 1.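

Compound 1 gives only a limit in this assay, > 100 mg/kg. Shortening butyl to propyl yields a measured number for a chain of this length on the aromatic nitrogen, and the change reads as an at least 1.3-fold lower number from compound 1 to compound 4 (0.13 log units; that floor lies within the scatter). Adding a carbon to this chain now goes with a higher number in two pairs of compounds, with no pair shown going against it, though one of the two steps has a floor that lies within the scatter: the same change on two cores in this assay, a 2.1-fold higher number (0.33 log units; beyond the scatter) from compound 2 to compound 3 and an at least 1.3-fold higher number (0.13 log units; that floor lies within the scatter) from compound 4 to compound 1; the limit leaves it open whether they differ

On these data alone, the true size of the step between butyl and propyl stays open, and so does whether the two pairs differ. Also open, as far as these compounds go, is how a branched chain such as isopropyl, or a chain ending in an amine or a carboxylic acid, would fare on this nitrogen.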